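Pyridinylmethyl replaces propyl on the benzindazole-type nitrogen

The source may hold more compounds than are shown below. What is called first, only, known or untested is meant among the compounds shown, and "the series" means these compounds.

Measured compounds in a functional assay on HCT-116 cells (Homo sapiens) for antiproliferative activity, read by MTT assay, with a stated time of 72 h; a lower number here means a stronger inhibitor of growth, a higher number a weaker inhibitor of growth:
compound 1 `Cn1nc(-c2ccnc(Nc3ccc(S(N)(=O)=O)cc3)n2)c2ccccc21` gives 2280 nM;
compound 2 `Cn1nc(-c2ccnc(Nc3cccc(S(N)(=O)=O)c3)n2)c2ccccc21` gives 1980 nM;
compound 3 `CCCn1nc(-c2ccnc(Nc3cccc(S(N)(=O)=O)c3)n2)c2ccccc21` gives 7950 nM.

Compound 3 stands highest of the three numbers, above compound 1 and compound 2 alike, and both gaps lie beyond the scatter. For the measured compounds named here, the one measured step that touches the same position is the one a 4.0-fold higher number from compound 2 to compound 3 (0.60 log units; beyond the scatter), where a methyl on the aromatic nitrogen grows to a propyl. Compound 4 `NS(=O)(=O)c1cccc(Nc2nccc(-c3nn(Cc4cccnc4)c4ccccc34)n2)c1` carries the change (pyridin-3-yl in place of ethyl on a saturated chain carbon bound to an aromatic nitrogen); cut one bond further out it reads propyl to (pyridin-3-yl)methyl. Going by the values given here, no measured pair shows an aromatic ring at this place, so the step can only be bounded loosely. The step from compound 2 to compound 3 shows that lengthening the chain here cost potency; a still larger substituent might cost again, but the new ring also brings an acceptor, and nothing in this assay says how that is read. Compound 4 is therefore expected to come out near compound 3, with a 1.0-fold higher number from compound 3 to compound 4 (0.00 log units; within the scatter) taken as no step beyond the scatter in either direction, but with a wide range. Compound 4 is estimated at 8000 nM, between 2500 nM and 25000 nM.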

Compound 4, concentration for 50% growth inhibition: 8280 nM
Compound 4: the middle estimate sits 1.0-fold (0.01 log units) below what was measured; measured number inside the range.
By their numbers in this assay, from the lowest: compounds 2 and 1 (each within the scatter of the next); then compounds 3 and 4 (each within the scatter of the next).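

In this assay, the step of a 1.0-fold higher number from compound 3 to compound 4 (0.02 log units; within the scatter) shows that this position accepts pyridin-3-yl in place of ethyl, with its aromatic ring and hydrogen-bond acceptor, without any change that can be told from scatter. Measured against the methyl compound, the step of a 4.2-fold higher number from compound 2 to compound 4 (0.62 log units; beyond the scatter) lies beyond the scatter, as does a 4.0-fold higher number from compound 2 to compound 3 (0.60 log units; beyond the scatter), so the loss seen with propyl recurs with (pyridin-3-yl)methyl, yet the larger group adds nothing measurable to that loss beyond what propyl already shows. The data offer no independent evidence that would explain this flat response to the added ring.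

Going by these compounds, what remains open is whether the ring nitrogen matters at all, since a plain phenyl on the same chain carbon would separate the effect of the ring from that of its nitrogen, and pyridin-2-yl or pyridin-4-yl would test where that nitrogen sits. On these data alone, it also remains unknown whether an amine or a carboxylic acid at the end of a chain on this nitrogen would read like propyl and (pyridin-3-yl)methyl or would move the number in either direction.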